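The source may hold more compounds than are shown below. What is called first, only, known or untested is meant among the compounds shown, and "the series" means these compounds.

Three compounds have been measured in a functional assay on PA-1 cells (Homo sapiens) for cytotoxicity, read by MTT assay, with stated times of 6 h and 48 h; a higher number here means a weaker inhibitor, a lower number a stronger inhibitor:

compound 1, `Cn1c(/C=C/C(=O)c2ccccc2O)cc(Br)c1Br`, giving 1250 nM
compound 2, `COc1ccc(OC)c(C(=O)/C=C/c2cc(Br)c(Br)n2C)c1`, giving 800 nM
compound 3, `O=C(/C=C/c1cc(Br)c(Br)[nH]1)c1ccccc1O`, giving 330 nM

Compound 3 differs from compound 1 by one change, (hydrogen in place of methyl on an aromatic nitrogen), and that change brought a 3.8-fold lower number from compound 1 to compound 3 (0.58 log units; beyond the scatter) in this assay. Compound 2 and compound 1 share the same five-membered ring but carry different aryl ketone portions; how the two cores differ is not broken down here. The value of compound 2 lies within the scatter of that of compound 1, and beyond the scatter of that of compound 3.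

Compound 4, `COc1ccc(OC)c(C(=O)/C=C/c2cc(Br)c(Br)[nH]2)c1`, has not yet been measured. It is related to compound 2 by hydrogen in place of methyl on an aromatic nitrogen, the same change, at the same place in the ring, as that from compound 1 to compound 3. Among the measured compounds shown here, the expectation is therefore a step of about a 3.5-fold lower number from compound 2 to compound 4 (0.54 log units; beyond the scatter) in this assay, resting on the single measured instance a 3.8-fold lower number from compound 1 to compound 3 (0.58 log units; beyond the scatter) from compound 1 to compound 3. On that basis compound 4 is estimated to give 230 nM in this assay, most likely between 100 nM and 600 nM.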

Compound 4, half-maximal inhibitory concentration: 420 nM
For compound 4 the middle estimate is 1.8-fold (0.26 log units) below the measured one, within the range that was stated.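

On the core of compound 2, hydrogen in place of methyl on the aromatic nitrogen comes out as a 1.9-fold lower number from compound 2 to compound 4 (0.28 log units; within the scatter) in this assay, so on this core alone the step cannot be told apart from the scatter of repeated measurements. Set beside the step on the core of compound 1, its size is not distinguishable, and nothing here shows that the different aryl ketone portions alter what the change does: the same change on two cores in this assay, a 3.8-fold lower number (0.58 log units; beyond the scatter) from compound 1 to compound 3 and a 1.9-fold lower number (0.28 log units; within the scatter) from compound 2 to compound 4, 2.0-fold (0.30 log units) apart, within the scatter of two such steps. Among the compounds shown here, this rests on only two pairs, however, so it does not show that the step has one fixed size, nor that it would carry to any other core.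

The compounds shown leave open what an ethyl group, a longer chain or an acetyl group on the aromatic nitrogen would do in place of methyl or hydrogen. They also leave open the effect of chloro or nitrile in place of a bromo group, and of an amine or a carboxylic acid on the aryl ketone portion.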